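From Dihydroxypropyl Ester to Cyclic Carbonate

The source may hold more compounds than are shown below. What is called first, only, known or untested is meant among the compounds shown, and "the series" means these compounds.

In a physicochemical assay for lipophilicity, read by HPLC, measured as chromatographic lipophilicity (on this read-out lower numbers stand for lower lipophilicity and higher numbers for higher lipophilicity), compound 1 (`CCC/N=C1\S/C(=C\c2ccc(C(=O)NCC(=O)N(C)C)cc2)C(=O)N1c1ccccc1O`) gives 1.9 and compound 2 (`CCC/N=C1\S/C(=C\c2ccc(C(=O)OCC(O)CO)cc2)C(=O)N1c1ccccc1O`) gives 1.8, so the two stand within the scatter of each other. Compound 3 (`CCC/N=C1\S/C(=C\c2ccc(C(=O)OCC3COC(=O)O3)cc2)C(=O)N1c1ccccc1O`) carries 2-oxo-1,3-dioxolan-4-yl in place of 1,2-dihydroxyethyl on a saturated chain carbon bound to an oxygen next to a carbonyl group. For the measured compounds named here, the only measured step, a number 0.10 log units lower from compound 1 to compound 2 (within the scatter), is a different exchange on a carbonyl carbon and offers a weak guide to size. Going by the values given here, no measured step covers this change, so the direction rests on the counted difference alone. In this assay, the expected step is a number 0.60 log units higher from compound 2 to compound 3 (beyond the scatter). Compound 3 is estimated at 2.4, with an expected range of 1.9 to 3.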

Compound 3, distribution coefficient: 2.8
For compound 3 the middle estimate is 0.40 log units below the measured one, within the range that was stated.
By their numbers in this assay, from the lowest: compounds 2 and 1 (each within the scatter of the next); then compound 3.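

In this assay, for the compounds shown here, 2-oxo-1,3-dioxolan-4-yl in place of 1,2-dihydroxyethyl on a saturated chain carbon bound to an oxygen next to a carbonyl group gives a number 1.00 log units higher from compound 2 to compound 3 (beyond the scatter), the first step beyond the scatter. (2-Oxo-1,3-dioxolan-4-yl)methoxy in place of ((dimethylcarbamoyl)methyl)amino on a carbonyl carbon gives a number 0.90 log units higher from compound 1 to compound 3 (beyond the scatter), so the closeness of compounds 1 and 2 does not extend to every group at that carbonyl carbon. Nothing at hand accounts for the size of these steps. Still open, from the compounds shown here alone, is how a carboxylic acid, an amine or a longer chain on that saturated chain carbon would read in this assay.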